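Phenyl in place of (tert-butoxy)methyl on compound 1

The source may report more compounds than this note shows. Statements on the series, on what has been measured and on what is new or still open speak of the compounds shown alone.

Measured in an ADME assay on liver for metabolic stability, with Liver microsome (Homo sapiens) as the target, read by LC-MS, using microsomes (on this read-out higher numbers stand for fast clearance and lower numbers for slow clearance), as follows:
- compound 1 `CC(C)(C)OC[C@@H](O)C(=O)N1[C@H](C(=O)NCc2cc(Cl)ccc2-n2cnnn2)C[C@@H]2C[C@@H]21` gives 21 mL.min-1.g-1 as a number
- compound 2 `CC(C)(C)[C@@H](O)C(=O)N1C[S+]([O-])C[C@H]1C(=O)NCc1cc(Cl)ccc1-n1cnnn1` gives < 12 mL.min-1.g-1 as a limit of the assay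
- compound 3 `CC(C)(C)[C@@H](O)C(=O)N1CSC[C@H]1C(=O)NCc1cc(Cl)ccc1-n1cnnn1` gives 120 mL.min-1.g-1 as a number

Of the two true numbers, compound 1 holds the lower one, and compound 3 lies higher, beyond the scatter. The next compound is compound 4 `O=C(NCc1cc(Cl)ccc1-n1cnnn1)[C@@H]1C[C@@H]2C[C@@H]2N1C(=O)[C@H](O)c1ccccc1` and the change phenyl in place of (tert-butoxy)methyl on a saturated chain carbon bound to a carbonyl carbon and an oxygen on a saturated carbon puts phenyl in place of (tert-butoxy)methyl on a saturated chain carbon bound to a carbonyl carbon and an oxygen on a saturated carbon. Going by the values given here, no measured pair shows this exchange, so the expected 1.2-fold higher number from compound 1 to compound 4 (0.08 log units; within the scatter) is none beyond the scatter. The estimate for compound 4 is 25 mL.min-1.g-1 as the expected clearance in this assay with an expected range (12 mL.min-1.g-1 to 60 mL.min-1.g-1).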

Compound 4, intrinsic clearance in microsomes: < 16 mL.min-1.g-1
Compound 4 was reported as a limit (the forecaster's own chance of this, stated with the estimate: 15%); middle value at least 1.5-fold (0.19 log units) from the limit.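

In this assay, phenyl in place of (tert-butoxy)methyl on this saturated chain carbon gives an at least 1.3-fold lower number from compound 1 to compound 4 (0.11 log units; that floor lies within the scatter), the first read of this position on the core of compound 1. The exchange brings an aromatic ring and removes the ether oxygen with no rise in clearance. Compound 4 gives a limit, not a number, so the true size of the step cannot be read: the limit of < 16 mL.min-1.g-1 in this assay, at which 1 of the 4 values shown sits.

From the compounds shown here alone, how a pyridine ring or an amine would read at this carbon remains open, as does whether a substituted phenyl would keep clearance this low.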